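The source may report more compounds than this note shows. Statements on the series, on what has been measured and on what is new or still open speak of the compounds shown alone.

Of the compounds shown here, three sharing a thioether-bearing benzamide core have been tested in an ADME assay on CEM-SS cells (Homo sapiens) for cytotoxicity, read by XTT assay, with a stated time of 6 days (a higher number here means that more compound is tolerated, a lower number that less compound is tolerated), and a fourth is still to be measured. Compound 1, `NC(=O)CCNC(=O)c1cccc(S)c1`, is the smallest of the set; in this assay compound 1 reaches only the assay limit of > 100 uM, and that is a limit rather than a number. Of the two numbers that were obtained, compound 2, `CCCC(=O)OCSc1ccccc1C(=O)NCCCCCNC(C)=O`, gives the lower one, 9.2 uM, meaning that less of it is tolerated by the cells. Compound 3, `CCCC(=O)OCSc1ccccc1C(=O)Nc1ccc(C(N)=O)cc1`, which carries an aromatic amide in place of the chain, gives 39 uM, a higher number by a margin beyond the usual scatter of repeated measurements.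

Compound 4, `CCCC(=O)OCSc1ccccc1C(=O)NCC(=O)NC(C)C`, is built from compound 2 by one change: isopropylcarbamoyl in place of 4-acetamidobutyl on a saturated chain carbon bound to an amide-type nitrogen. Within the data shown here, no measured pair here isolates this kind of shortening of the amide side chain, so the direction is uncertain. Among the measured compounds shown here, with the only comparison being that compound 3 gives 39 uM against compound 2 at 9.2 uM, a modest rise in tolerated concentration is expected, and compound 4 is estimated at 18 uM, between 6 uM and 55 uM, a step of a 2.0-fold higher number from compound 2 to compound 4 (0.29 log units; within the scatter) that is expected to stay near the scatter.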

Compound 4, half-maximal toxic concentration: 92 uM
For compound 4 the middle estimate is 5.1-fold (0.71 log units) below the measured one; measured number outside the range, above it.
By their numbers in this assay, from the lowest: compound 2; then compound 3; then compound 4. At a limit, above all of these: compound 1.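

Among these compounds, this is the first pair in the set that differs in one place only, so the group on the saturated chain carbon bound to an amide-type nitrogen can now be judged on its own. In this assay, placing isopropylcarbamoyl where 4-acetamidobutyl stood gives a 10-fold higher number from compound 2 to compound 4 (1.00 log units; beyond the scatter), so cell tolerance clearly depends on what sits at this place. By the counts, the two groups match in hydrogen-bond donors and acceptors, neither has a ring or a net charge, and the group entering has 6 heavy atoms against 8 for the one leaving.

A single pair cannot say how tolerance would change with an amine, a carboxylic acid or a longer chain at this place. Compound 1 offers no number for comparison, only a limit: the limit of > 100 uM in this assay, at which 1 of the 4 values shown sits.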